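The source may hold more compounds than are shown below. What is called first, only, known or untested is meant among the compounds shown, and "the series" means these compounds.

Compound 1, `CNC(=O)c1cc(C(=O)NC2CCC2)cn(Cc2cccc(NC)c2)c1=O`, 3.6; compound 2, `CNC(=O)c1cc(C(=O)NC2CC2)c(C)n(Cc2ccccc2)c1=O`, 2.9.

Of these two numbers in a physicochemical assay for lipophilicity, at pH 7.4 (a higher number here means a more lipophilic compound, a lower number a more polar compound), compound 1 stands highest; compound 2 sits lower by an amount beyond the usual scatter. Compound 3, `CNC(=O)c1cc(C(=O)NC2CCC2)cn(Cc2ccccc2)c1=O`, has not yet been measured. It differs from compound 1 in one place: hydrogen in place of methylamino on an aromatic carbon. Among the compounds with values here, no two measured compounds differ in just one place, so no measured step guides this particular change. A small upward step in this assay is expected, a number 0.40 log units higher from compound 1 to compound 3 (beyond the scatter), rather than none. Compound 3 is accordingly estimated at 4, within a range of 3.5 to 4.5.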

Compound 3, distribution coefficient: 3.8
Compound 3: middle estimate off by 0.20 log units, on the high side; measured number inside the range.
By their numbers in this assay, from the lowest: compound 2; then compounds 1 and 3 (each within the scatter of the next).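

In this assay the swap of methylamino for hydrogen on an aromatic carbon gives a number 0.20 log units higher from compound 1 to compound 3 (within the scatter) and so leaves the two compounds indistinguishable. Within the data shown here, this is the first direct comparison at this position, and it shows that, for this pair, the methylamino group and a bare hydrogen cannot be told apart on this measure. Nothing available explains why the two compounds read alike. From the compounds shown here alone, whether a carboxylic acid or a longer chain at this same carbon would also read alike remains open. Also open, going by these compounds, is whether the same swap would give a similar result on the core of compound 2.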